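Adding a Trifluoromethyl Group to Compound 1

The source may report more compounds than this note shows. Statements on the series, on what has been measured and on what is new or still open speak of the compounds shown alone.

Compound 1 `c1ccc(-c2cn3ccnc3c(-c3ccc4ncn(C5CCCCC5)c4c3)n2)cc1` gives 41.5% in a functional assay on MDA-MB-231 cells (Homo sapiens) for inhibition, read by sulforhodamine B assay, with a stated time of 48 h, tested at 10 uM (on this read-out lower numbers stand for less inhibition and higher numbers for more inhibition at the one concentration tested (going by the name of the read-out)), the highest of the three numbers measured. Compound 2 `c1cn2cc(-c3ccsc3)nc(-c3ccc4ncn(C5CCCCC5)c4c3)c2n1` gives 1.35% in this assay, and compound 3 `c1csc(-c2cn3ccnc3c(-c3ccc4ncn(C5CCCCC5)c4c3)n2)c1` gives 10.8%. Both measured steps exchange the whole phenyl for another ring: a number 40.2 percentage points lower from compound 1 to compound 2 (beyond the scatter) and a number 30.7 percentage points lower from compound 1 to compound 3 (beyond the scatter). Compound 4 `FC(F)(F)c1cccc(-c2cn3ccnc3c(-c3ccc4ncn(C5CCCCC5)c4c3)n2)c1` keeps the phenyl and only adds a substituent: trifluoromethyl in place of hydrogen on an aromatic carbon. Going by the values given here, no measured step adds a group to the phenyl while leaving the ring in place, so the two large steps give little guidance here. The step is therefore expected to be small, a number 1.5 percentage points lower from compound 1 to compound 4 (within the scatter), within the scatter. Compound 4 is estimated at 40%, in a range from 15% to 65%.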

Compound 4, a percentage reported as inhibition, at one concentration (the size of the read-out at that concentration, not a potency): 21.8%
Compound 4: the middle estimate sits 18.2 percentage points above what was measured, and the stated range covers the measured number.
By their numbers in this assay, from the lowest: compounds 2 and 3 (each within the scatter of the next); then compound 4; then compound 1.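

In this assay, a substituent on the phenyl changes the result even though the ring stays in place (a number 19.7 percentage points lower from compound 1 to compound 4 (beyond the scatter)). The substituted ring is not equivalent to the thiophene rings either, as compound 4 reads beyond the scatter of both (a number 11 percentage points higher from compound 3 to compound 4 (beyond the scatter); a number 20.5 percentage points higher from compound 2 to compound 4 (beyond the scatter)), so adding to the phenyl costs less here than replacing it. No measured evidence shows what lies behind this loss.

The compounds shown leave open whether the loss is particular to trifluoromethyl. An amine, a methoxy group or a carboxylic acid in place of the same hydrogen could answer that.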